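A few compounds are considered here, and "the series" means these few. Any claim that something is new, unique, unknown or untested is made for them only; others in the source may bear on it.

Compound 1 `O=C(/C=C/c1c[nH]c2ccccc12)c1ccncc1` gives > 150000 nM in an ADME assay on HEK293 cells (Homo sapiens) for antiproliferative activity, read by MTT assay, with a stated time of 48 h (a lower number here means a stronger inhibitor, a higher number a weaker inhibitor), as a limit, not a number. Compound 2 `O=C(/C=C/c1cn(S(=O)(=O)c2ccc([N+](=O)[O-])cc2)c2ccccc12)c1ccncc1` gives > 150000 nM in this assay as a limit too. Compound 3 `O=C(/C=C/c1cn(S(=O)(=O)c2cccc([N+](=O)[O-])c2)c2ccccc12)c1ccncc1` also gives only a limit, > 150000 nM once more. The whole picture so far is the limit of > 150000 nM in this assay, at which 3 of the 3 values shown sit, and nothing finer.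

Compound 4 `O=C(/C=C/c1cn(S(=O)(=O)c2ccccc2[N+](=O)[O-])c2ccccc12)c1ccncc1` has not been measured and carries 2-nitrophenyl in place of 3-nitrophenyl on a sulfonyl sulfur, counted as 2-nitrophenyl in place of 3-nitrophenyl on a sulfonyl sulfur in comparing the two. Among the compounds with values here, the one measured step of this kind is a step that the two limits leave unreadable from compound 2 to compound 3 for 3-nitrophenyl in place of 4-nitrophenyl on a sulfonyl sulfur, so it offers no size to carry over. Hence no step beyond the scatter is expected in this assay and no direction can be given. The estimated change is a number no higher from compound 3 to compound 4 (the limit leaves the size open) on this reasoning. Compound 4 is estimated at 150000 nM within a range of 80000 nM to 300000 nM and is expected to report only a limit.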

Compound 4, half-maximal inhibitory concentration: > 150000 nM
Compound 4 gave a limit, no number (the forecaster's own chance of this, stated with the estimate: 85%); the middle value sits exactly at the limit.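

No step among compound 2, compound 3 and compound 4 can be read, because each gives only a limit: the limit of > 150000 nM in this assay, at which 4 of the 4 values shown sit.

The compounds shown leave open whether 2-nitrophenyl, 3-nitrophenyl and 4-nitrophenyl differ at all in this assay.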